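Swapping the Sulfonyl Aryl Group in a Benzimidazole Sulfonamide

This account rests on a few compounds, and the source may have more. Where it says the series, first, only, none or still open, it means among the compounds named here.

compound 1, `CCn1c([C@@H](C)NS(=O)(=O)c2ccc(Cl)cc2)nc2cc(F)c(Cl)cc21`: > 100 mL.min-1.g-1
compound 2, `CCn1c([C@@H](C)NS(=O)(=O)c2ccc(CC(C)C)cc2)nc2ccc(C(F)(F)F)cc21`: > 100 mL.min-1.g-1

Two compounds have so far been run in an ADME assay (liver) for metabolic stability, with Liver microsome (Homo sapiens) as the target, read by LC-MS, using microsomes and NADPH, with a stated time of 5 min, at 37 degrees C; on this read-out higher numbers stand for fast clearance and lower numbers for slow clearance. Compound 1 gives > 100 mL.min-1.g-1, which is a limit of the assay rather than a number. Compound 2 likewise gives > 100 mL.min-1.g-1, again a limit and not a measured number. Both values therefore sit at the same edge of the assay, as summed up by the limit of > 100 mL.min-1.g-1 in this assay, at which 2 of the 2 values shown sit, so compound 2 stands at the top of what this assay can report, with no room to rank it against compound 1.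

The next compound, compound 3 `CCn1c([C@@H](C)NS(=O)(=O)c2cnc(NC(C)=O)s2)nc2ccc(C(F)(F)F)cc21`, differs from compound 2 in one place: 2-acetamido-1,3-thiazol-5-yl in place of 4-isobutylphenyl on a sulfonyl sulfur. Since compound 2 only has a limit, the size of this step can only be estimated. The step of an at least 2.2-fold lower number from compound 2 to compound 3 (0.34 log units; beyond the scatter) is expected to be a drop in clearance of modest size. Compound 3 is estimated at 45 mL.min-1.g-1, between 12 mL.min-1.g-1 and 150 mL.min-1.g-1.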

Compound 3, intrinsic clearance in microsomes: 15 mL.min-1.g-1
Compound 3: the middle estimate sits 3.0-fold (0.48 log units) above what was measured; low and high end bracket the measured number.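

In this assay, going by these compounds alone, compound 3 is the only one of the three compounds that gives a real number rather than a value at the edge of the assay, which shows that the group on the sulfonyl sulfur can move this read-out: the limit of > 100 mL.min-1.g-1 in this assay, at which 2 of the 3 values shown sit. Replacing 4-isobutylphenyl with 2-acetamido-1,3-thiazol-5-yl gives an at least 6.6-fold lower number from compound 2 to compound 3 (0.82 log units; beyond the scatter). Compound 2 gives > 100 mL.min-1.g-1, which is a limit and not a number, so the step could be larger than the one printed.

Because the whole group changes at once, the compounds shown cannot say whether the ring or the acetamido part matters more; a phenyl ring carrying an acetamido group, or a thiazole carrying a free amine, would separate the two. On these data alone, whether the same swap works on the core of compound 1 also remains open.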